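The source may hold more compounds than are shown below. What is called first, only, known or untested is meant among the compounds shown, and "the series" means these compounds.

Measured compounds:
compound 1 `Cc1ccc(OCc2cn(Cc3ccc([N+](=O)[O-])cc3)nn2)cc1`: 10.9 ug/mL
compound 2 `Cc1ccc(OCc2cn(Cc3cccc([N+](=O)[O-])c3)nn2)cc1`: 12.1 ug/mL
compound 3 `O=[N+]([O-])c1ccc(Cn2cc(COc3ccc(Cl)cc3)nn2)cc1`: 24.2 ug/mL

All three numbers come from a physicochemical assay, read by spectrophotometry, with a stated time of 30 min; on this read-out lower numbers stand for stronger inhibition and higher numbers for weaker inhibition. Compound 1 and compound 3 share a core and differ in one place: chloro in place of methyl on an aromatic carbon. That change gave a 2.2-fold higher number from compound 1 to compound 3 (0.35 log units; beyond the scatter). Compound 2 has the same atoms as compound 1 joined differently; the difference between the two cores is not broken down here. In this assay compound 2 gives a number within the scatter of both compound 1 and compound 3, so no order among the three is drawn.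

Compound 4 `O=[N+]([O-])c1cccc(Cn2cc(COc3ccc(Cl)cc3)nn2)c1` is not yet measured. It relates to compound 2 as compound 3 relates to compound 1: chloro in place of methyl on an aromatic carbon. The place of the change reads the same word for word in both pairs, so this is the same change, seen once so far in a measured pair. Because a 2.2-fold higher number from compound 1 to compound 3 (0.35 log units; beyond the scatter) lay beyond the scatter, a step of similar size is expected, a 2.1-fold higher number from compound 2 to compound 4 (0.33 log units; beyond the scatter). This rests on a single measured pair, so the margin is kept wide. Compound 4 is expected at 26 ug/mL, with a range from 15 ug/mL to 45 ug/mL.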

Compound 4, half-maximal inhibitory concentration: 21.3 ug/mL
For compound 4 the middle estimate is 1.2-fold (0.09 log units) above the measured one; measured number inside the range.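

In this assay, chloro in place of methyl on an aromatic carbon gives a 1.8-fold higher number from compound 2 to compound 4 (0.25 log units; within the scatter), whereas on the core of compound 1 the same change gave a 2.2-fold higher number from compound 1 to compound 3 (0.35 log units; beyond the scatter). The change therefore has no effect on the core of compound 2 that can be told apart from the usual scatter, so the step beyond the scatter seen on the core of compound 1 is not confirmed on this second core, though this pair does not rule out a small shift of the same kind; two pairs cannot establish a rule for the series. No measurement is at hand that bears on why the two steps read as they do.

Open, on these data alone, is how other groups on that aromatic carbon would read on these two cores, for example an amine, a carboxylic acid or a longer chain such as propyl in place of methyl. Also open, as far as these compounds go, is whether the two steps would read the same way in a different assay.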